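Working notes: methoxymethyl to ethoxymethyl at compound 4

A few compounds are considered here, and "the series" means these few. Any claim that something is new, unique, unknown or untested is made for them only; others in the source may bear on it.

Measured in a physicochemical assay for lipophilicity; a higher number here means a more lipophilic compound, a lower number a more polar compound:
- compound 1 `CCOC[C@H](Oc1ncnc2c1cnn2-c1ncccc1Cl)C(=O)Nc1ccccn1`: 2.1
- compound 2 `CCOC[C@H](Oc1ncnc2c1cnn2-c1ncccc1Cl)C(=O)Nc1ccc(C#N)cn1`: 2
- compound 3 `COC[C@H](Oc1ncnc2c1cnn2-c1ncccc1Cl)C(=O)Nc1cnc(C)cn1`: 1.4

In this assay compound 3 stands lowest of the three at 1.4, and its gaps to compound 1 and compound 2 are beyond the scatter. Compound 4 `CCOC[C@H](Oc1ncnc2c1cnn2-c1ncccc1Cl)C(=O)Nc1cnc(C)cn1` is compound 3 with methoxymethyl changed to ethoxymethyl: methyl in place of hydrogen on a saturated chain carbon bound to an oxygen on a saturated carbon.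

Among the compounds with values here, the only measured step, a number 0.10 log units lower from compound 1 to compound 2 (within the scatter), is a different exchange, so it gives no size for this one. Compound 1 at 2.1 and compound 2 at 2 carry ethoxymethyl, but both also differ from compound 3 in the amide group. Their gap to compound 3 therefore cannot be assigned to the chain alone. A moderate rise in this assay is expected, smaller than that gap. The expected step is a number 0.40 log units higher from compound 3 to compound 4 (beyond the scatter). For compound 4 the estimated value is 1.8, with an expected range of 1.5 to 2.2.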

Compound 4, distribution coefficient: 1.8
Beside the measured number, compound 4's estimate shows no gap at the digits printed; low and high end bracket the measured number.
By their numbers in this assay, from the lowest: compound 3; then compounds 4, 2 and 1 (each within the scatter of the next).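

In this assay, the change from methoxymethyl to ethoxymethyl now has a size of its own with the amide group held at 5-methylpyrazin-2-yl: it gives a number 0.40 log units higher from compound 3 to compound 4 (beyond the scatter) as the step for methyl in place of hydrogen at this chain carbon. With ethoxymethyl held, 5-methylpyrazin-2-yl in place of 5-cyanopyridin-2-yl gives a number 0.20 log units lower from compound 2 to compound 4 (within the scatter) and 5-methylpyrazin-2-yl in place of pyridin-2-yl gives a number 0.30 log units lower from compound 1 to compound 4 (within the scatter) as its step, so among these three steps only the chain change lies beyond the scatter. Nothing available explains the size of any of these steps.

On these data alone, whether the chain step keeps this size with pyridin-2-yl or 5-cyanopyridin-2-yl on the amide nitrogen remains open. Also open, as far as these compounds go, is how a longer chain such as propoxymethyl, or a carboxylic acid at the chain end, would read in this assay at this position.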